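A few compounds are considered here, and "the series" means these few. Any claim that something is new, unique, unknown or untested is made for them only; others in the source may bear on it.

Three compounds share one core and differ only in the group attached to the carbonyl carbon of the amide. Compound 1 `CCN(CC)CCNC(=O)c1ccc(C(CC)(CC)c2ccc(OCC(O)C(C)(C)C)c(C)c2)n1CC` carries a (2-(diethylamino)ethyl)amino group there; in a functional assay on HepG2 cells (Homo sapiens), read by MTT assay, with a stated time of 48 h (on this read-out lower numbers stand for stronger inhibition and higher numbers for weaker inhibition), compound 1 gives 490 nM, the lowest of the three numbers. Compound 2 `CCN(CC)CCCNC(=O)c1ccc(C(CC)(CC)c2ccc(OCC(O)C(C)(C)C)c(C)c2)n1CC` extends that chain by one carbon and gives 1100 nM, a step of a 2.2-fold higher number from compound 1 to compound 2 (0.35 log units; beyond the scatter). Compound 3 `CCn1c(C(=O)N(CCC#N)CCC#N)ccc1C(CC)(CC)c1ccc(OCC(O)C(C)(C)C)c(C)c1` replaces the whole group on the carbonyl carbon and gives 42000 nM, a step of an 86-fold higher number from compound 1 to compound 3 (1.93 log units; beyond the scatter); from compound 2 the step is a 38-fold higher number from compound 2 to compound 3 (1.58 log units; beyond the scatter).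

Compound 4 `CCn1c(C(=O)N(C)CC(=O)O)ccc1C(CC)(CC)c1ccc(OCC(O)C(C)(C)C)c(C)c1` is the unmeasured one. Relative to compound 1 the change is (carboxymethyl)(methyl)amino in place of (2-(diethylamino)ethyl)amino on a carbonyl carbon. Among the compounds with values here, the step most like it is the one from compound 1 to compound 3, where the group on the carbonyl carbon was also exchanged entirely rather than lengthened, and the number rose by an 86-fold higher number from compound 1 to compound 3 (1.93 log units; beyond the scatter). The step from compound 1 to compound 2, which only lengthens the chain, was far smaller and so weighs less here. Because the step of an 86-fold higher number from compound 1 to compound 3 (1.93 log units; beyond the scatter) was large, a large rise is expected for compound 4 too, though the new group is smaller than that of compound 3, so the rise is estimated somewhat below it: a 41-fold higher number from compound 1 to compound 4 (1.61 log units; beyond the scatter). For compound 4 the estimate in this assay is 20000 nM, with a range from 5000 nM to 80000 nM.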

Compound 4, half-maximal inhibitory concentration: 17100 nM
For compound 4 the middle estimate is 1.2-fold (0.07 log units) above the measured one; low and high end bracket the measured number.
By their numbers in this assay, from the lowest: compound 1; then compound 2; then compound 4; then compound 3.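

With compound 4, a second group without the diethylamino end has been tested on the carbonyl carbon, and in this assay it also gives a much higher number: a 35-fold higher number from compound 1 to compound 4 (1.54 log units; beyond the scatter), and a 16-fold higher number from compound 2 to compound 4 (1.19 log units; beyond the scatter). Among these four compounds, the two carrying a diethylamino group therefore give the lower numbers, and none goes against this, even though the groups in compound 3 and compound 4 share little else; between those two the step is only a 2.5-fold lower number from compound 3 to compound 4 (0.39 log units; beyond the scatter), which is beyond the scatter but modest. No measurement here explains why these exchanges raise the number so strongly.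

Compound 3 and compound 4 also both lack the amide hydrogen present in compound 1 and compound 2, so the loss of the diethylamino group and the loss of that hydrogen cannot be told apart. A (2-(diethylamino)ethyl)(methyl)amino group would keep the amine without the amide hydrogen, while a (carboxymethyl)amino group would keep the hydrogen and the carboxylic acid without the amine, and the compounds shown do not say how either would behave.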